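The source may hold more compounds than are shown below. What is called first, only, known or untested is meant among the compounds shown, and "the series" means these compounds.

Working notes on the series. Of the compounds shown here, two built on a shared core have numbers so far. In a functional assay on HCT-116 cells (Homo sapiens) for antiproliferative activity, read by resazurin assay, with a stated time of 5 days (a higher number here means a weaker inhibitor, a lower number a stronger inhibitor), compound 1 (`O=C(CCCC1CCN(S(=O)(=O)c2ccccc2)CC1)NO`) gives 2700 nM, and compound 2 (`O=C(CCCC1CCN(C(=O)c2ccccc2)CC1)NO`) gives 17200 nM. Compound 2 therefore has the higher of the two numbers, making it the weaker inhibitor, and the gap lies beyond the usual scatter.

Compound 3 (`O=C(CCCC1CCN(C(=O)Nc2ccccc2)CC1)NO`) is the next structure to follow from compound 2. The change is anilino in place of phenyl on a carbonyl carbon, with anilino in place of phenyl on a carbonyl carbon. Among the compounds with values here, no measured pair shows what this change does on its own, so the expectation has little support. The two values give only a span, running from compound 1 at 2700 nM to compound 2 at 17200 nM.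

In this assay, a small step towards a lower number is expected, probably not beyond the scatter. The expected change is a 1.9-fold lower number from compound 2 to compound 3 (0.28 log units; within the scatter). For compound 3 the estimated value is 9000 nM, with an expected range of 3500 nM to 22000 nM.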

Compound 3, half-maximal inhibitory concentration: 700 nM
Beside the measured number, compound 3's estimate is 13-fold (1.11 log units) above it; measured number outside the range, below it.
By their numbers in this assay, from the lowest: compound 3; then compound 1; then compound 2.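

In this assay, within the data shown here, the position on a carbonyl carbon whose other neighbour is the amide-type nitrogen in a ring proves highly sensitive to what is attached there: anilino in place of phenyl gives a 25-fold lower number from compound 2 to compound 3 (1.39 log units; beyond the scatter), the first single change that can be read on its own. The aromatic ring of carbon only stays in both groups, so this step goes with the added nitrogen and its hydrogen-bond donor, along with the one extra heavy atom, and not with any exchange of the ring itself. That is a description of what differs between the two groups and not an explanation, as nothing in hand accounts for the size of this step.

Still open, going by these compounds, is whether the nitrogen hydrogen matters or whether any one-atom link to the phenyl ring would do, a question that phenoxy, methylphenylamino or benzylamino on the same carbonyl carbon would address. Also open, on these data alone, is how far the anilino ring tolerates substitution, for instance by a chlorine or a methoxy group, and whether this single step carries over to other chain lengths in the hydroxamic acid side chain.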